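Amino in place of methoxy: working notes on compound 3

A few compounds are considered here, and "the series" means these few. Any claim that something is new, unique, unknown or untested is made for them only; others in the source may bear on it.

Measured in (a functional assay on K562 cells (Homo sapiens) for cytotoxicity, read by MTT assay, with a stated time of 48 h; a higher number here means a weaker inhibitor, a lower number a stronger inhibitor):
Compound 1 (`COc1cc(-n2c(-c3ccc(O)cc3)c[nH]c2=O)cc(OC)c1OC`) (> 50000 nM)
Compound 2 (`COc1ccc(-c2c[nH]c(=O)n2-c2cc(OC)c(OC)c(OC)c2)cc1OC`) ("not determined" (no result reported))

The entry for compound 1 (> 50000 nM) is a limit of the assay, not a number. Compound 2 has no number on this scale, its result reading ("not determined" (no result reported)). Compound 3 (`COc1ccc(-c2c[nH]c(=O)n2-c2cc(OC)c(OC)c(OC)c2)cc1N`) awaits measurement. The change (amino in place of methoxy on an aromatic carbon) puts amino in place of methoxy on an aromatic carbon, ortho to a methoxy group. For the measured compounds named here, no measured step is available as a guide, but a large step towards stronger inhibition in (this assay) is expected, though compound 2 gives no number to count it from. For compound 3 the estimated value is (300 nM), with an expected range from (20 nM) to (8000 nM).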

Compound 3, half-maximal inhibitory concentration: 49200 nM
Compound 3: the middle estimate sits 160-fold (2.21 log units) below what was measured, and the stated range ends below it.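

In this assay compound 3 gives 49200 nM, so an amino group on this aromatic carbon, ortho to a methoxy group, leaves the series at the weak end of the scale. Compound 1 gives > 50000 nM, which is a limit of the assay and not a number. The one readable step is an at least 1.0-fold lower number from compound 1 to compound 3 (0.00 log units; that floor lies within the scatter), which separates the 3-amino-4-methoxyphenyl group from the 4-hydroxyphenyl group by nothing beyond the scatter, and the reading lies close to the ceiling: the limit of > 50000 nM in this assay, at which 1 of the 3 values shown sits.

As far as these compounds go, the step from compound 2 to compound 3 cannot be read, so the effect of amino in place of methoxy itself stays open. Also open, from the compounds shown here alone, is whether a dimethylamino group or an acetamide on this carbon would give a value clear of that limit.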